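A few compounds are considered here, and "the series" means these few. Any claim that something is new, unique, unknown or untested is made for them only; others in the source may bear on it.

In a functional assay on CCRF-CEM cells (Homo sapiens), read by MTT assay, with a stated time of 72 h (on this read-out lower numbers stand for stronger inhibition and higher numbers for weaker inhibition), compound 1 `CSc1ncnc2c1c(-c1ccoc1)cn2[C@@H]1O[C@H](CO)[C@@H](O)[C@H]1O` gives 14200 nM. Compound 2 `C#Cc1cn([C@@H]2O[C@H](CO)[C@@H](O)[C@H]2O)c2ncnc(SC)c12` is reported only as a limit, > 20000 nM. Compound 3 `CNc1ncnc2c1c(-c1ccoc1)cn2[C@@H]1O[C@H](CO)[C@@H](O)[C@H]1O` is also reported only as a limit, > 20000 nM, and so stands at the limit of > 20000 nM in this assay, at which 2 of the 3 values shown sit. Compound 4 `CNc1ncnc2c1c(-c1ccccc1)cn2[C@@H]1O[C@H](CO)[C@@H](O)[C@H]1O` changes one group of compound 3: phenyl in place of furan-3-yl on an aromatic carbon. One measured step also removes furan-3-yl, an at least 1.4-fold higher number from compound 1 to compound 2 (0.14 log units; that floor lies within the scatter), with ethynyl entering. The other, an at least 1.4-fold higher number from compound 1 to compound 3 (0.14 log units; that floor lies within the scatter), puts methylamino in place of methylsulfanyl. Neither involves phenyl, so no step beyond the scatter, in either direction, is expected in this assay. The expected change is a number no higher from compound 3 to compound 4 (the limit leaves the size open). For compound 4 the estimate is 20000 nM, with an expected range of 9000 nM to 45000 nM.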

Compound 4, half-maximal inhibitory concentration: > 20000 nM
Compound 4 ended at the assay's limit; the forecaster's own chance of this, stated with the estimate: 65%; the middle value lies on the limit itself.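

Compound 3 and compound 4 are both reported only as limits in this assay, and the step between them cannot be read. The compounds shown leave open how phenyl and furan-3-yl compare on this core.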